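Amide nitrogen variation and cytotoxicity in the proline series

A few compounds are considered here, and "the series" means these few. Any claim that something is new, unique, unknown or untested is made for them only; others in the source may bear on it.

Compound 3 `C[C@H](NC(=O)[C@]1(Cc2ccccc2)CCN1C(=O)OCc1ccccc1)C(=O)NC(C)(C)C` is the starting point of the next step. In an ADME assay on HELF cells (Homo sapiens) for cytotoxicity, with a stated time of 3 days (a lower number here means that less compound is tolerated, a higher number that more compound is tolerated), compound 3 gives > 100000 nM, which is a limit of the assay and not a number. Compound 1 `CC(C)C[C@H](NC(=O)[C@]1(Cc2ccccc2)CCN1C(=O)OCc1ccccc1)C(N)=O` gives 50000 nM in this assay. Compound 2 `C[C@H](NC(=O)[C@]1(Cc2ccccc2)CCN1C(=O)OCc1ccccc1)C(=O)NCc1ccccc1` gives 42000 nM in this assay; the move a 1.2-fold lower number from compound 1 to compound 2 (0.08 log units; within the scatter). The two steps reaching compound 3 are an at least 2.0-fold higher number from compound 1 to compound 3 (0.30 log units; that floor lies within the scatter) and an at least 2.3-fold higher number from compound 2 to compound 3 (0.37 log units; beyond the scatter); both rest on (the limit of > 100000 nM in this assay, at which 1 of the 3 values shown sits), so only a floor on the shift is known. Compound 3 thus stands at the upper edge of what this assay resolves, and all three measured compounds sit in a narrow band at the high end.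

Compound 4 `C[C@H](NC(=O)[C@]1(Cc2ccccc2)CCN1C(=O)OCc1ccccc1)C(=O)N(C)C` differs from compound 3 in that (dimethylamino in place of (tert-butyl)amino on a carbonyl carbon). The measured steps bearing on this change are those at the same amide-type nitrogen, an at least 2.3-fold higher number from compound 2 to compound 3 (0.37 log units; beyond the scatter) and an at least 2.0-fold higher number from compound 1 to compound 3 (0.30 log units; that floor lies within the scatter), together with a 1.2-fold lower number from compound 1 to compound 2 (0.08 log units; within the scatter); none of them removes the amide hydrogen, so they bound rather than fix the expectation, and nothing in them points to a large drop. The estimate for compound 4 in this assay is 70000 nM, with a range from 30000 nM to 200000 nM. The step this implies, an at least 1.4-fold lower number from compound 3 to compound 4 (0.15 log units; that floor lies within the scatter), is expected to be none beyond the scatter, with a fair chance that compound 4 again reaches only the limit.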

Compound 4, half-maximal cytotoxic concentration: > 100000 nM
Compound 4 ended at the assay's limit; the forecaster's own chance of this, stated with the estimate: 40%; at least 1.4-fold (0.15 log units) between middle value and limit.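

Going by these compounds alone, compound 4 gives > 100000 nM in this assay, which is a limit of the assay and not a number, so the top of the range is still reached with the amide hydrogen gone from this position, something no earlier compound could show. The readable steps are an at least 2.3-fold higher number from compound 2 to compound 4 (0.37 log units; beyond the scatter) and an at least 2.0-fold higher number from compound 1 to compound 4 (0.30 log units; that floor lies within the scatter), and only the first of these floors clears the scatter; tert-butyl is thus not required for this standing, and among compound 2, compound 3 and compound 4, only compound 2, with benzylamino, has a value inside the range. No size can be given for the change from (tert-butyl)amino to dimethylamino itself, because both of its ends sit at the limit: the limit of > 100000 nM in this assay, at which 2 of the 4 values shown sit.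

As far as these compounds go, how far compound 3 and compound 4 lie beyond that limit stays open, and so does any ordering between them. Also open, from the compounds shown here alone, is whether a morpholine ring or a carboxylic acid on this carbonyl carbon would stay at the limit as well or come down into the range where compound 2 lies.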